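The source may report more compounds than this note shows. Statements on the series, on what has been measured and on what is new or still open speak of the compounds shown alone.

Measured compounds and their values in a functional assay on HT-29 cells (Homo sapiens) for cytotoxicity, read by MTT assay, with a stated time of 72 h; on this read-out higher numbers stand for weaker inhibition and lower numbers for stronger inhibition:
- compound 1 `COc1ccc(OC)c(/C=N/NC(=O)Nc2ccc(Oc3ccnc(-c4nncn4CCN(C)C)c3)c(F)c2)c1`: 2070 nM
- compound 2 `COc1ccc(/C=N/NC(=O)Nc2ccc(Oc3ccnc(-c4nncn4CCN(C)C)c3)c(F)c2)c(OC)c1`: 1780 nM
- compound 3 `CN(C)CCn1cnnc1-c1cc(Oc2ccc(NC(=O)N/N=C/c3ccc(F)cc3F)cc2F)ccn1`: 960 nM

All three share one core and differ only in the aromatic ring attached to the carbon with a double bond to nitrogen. Compound 3 has the lowest of the three numbers, but its separation from compound 2 is a 1.9-fold lower number from compound 2 to compound 3 (0.27 log units; within the scatter), while its separation from compound 1 is a 2.2-fold lower number from compound 1 to compound 3 (0.33 log units; beyond the scatter); the two dimethoxy compounds sit close together, a 1.2-fold lower number from compound 1 to compound 2 (0.07 log units; within the scatter).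

Compound 4 `CN(C)CCn1cnnc1-c1cc(Oc2ccc(NC(=O)N/N=C/c3ccc(Cl)cc3)cc2F)ccn1` keeps everything except that ring: 4-chlorophenyl in place of 2,4-difluorophenyl on a carbon with a double bond to nitrogen. The measured steps bear on it only loosely, since all of them replace one aromatic ring by another at this same place, and the largest of them is modest. Moving from one halogenated ring to another is expected to change little; in this assay the step from compound 3 to compound 4 is estimated as a 1.1-fold lower number from compound 3 to compound 4 (0.03 log units; within the scatter), with no clear direction beyond the scatter. Compound 4 is therefore expected to give about 900 nM, within a range of 400 nM to 2000 nM.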

Compound 4, half-maximal inhibitory concentration: 530 nM
Beside the measured number, compound 4's estimate is 1.7-fold (0.23 log units) above it; the measured number falls inside the stated range.
By their numbers in this assay, from the lowest: compounds 4, 3, 2 and 1 (each within the scatter of the next, the first and the last beyond it).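

Through this assay, compound 4 gives the widest separations yet seen at this position: (a 3.4-fold lower number from compound 2 to compound 4 (0.53 log units; beyond the scatter)) and (a 3.9-fold lower number from compound 1 to compound 4 (0.59 log units; beyond the scatter)), both larger than any step among the earlier compounds. So 4-chlorophenyl stands clearly apart from both dimethoxyphenyl rings, whereas 2,4-difluorophenyl stood clearly apart from only one of them. The two halogenated rings themselves cannot be ranked, as (a 1.8-fold lower number from compound 3 to compound 4 (0.26 log units; within the scatter)) stays within the scatter. Nothing measured here explains why these rings give different numbers.

All four rings shown carry halogens or methoxy groups, so it remains open how an unsubstituted phenyl, or a ring bearing an amine or a carboxylic acid, would read. Also open, going by these compounds, is whether the chlorine counts for more than where it sits, which 3-chlorophenyl or 4-fluorophenyl could help to test.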